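Butoxy on compound 3: working notes

The source may report more compounds than this note shows. Statements on the series, on what has been measured and on what is new or still open speak of the compounds shown alone.

Values in a functional assay on MCF7 cells (Homo sapiens) for antiproliferative activity, read by sulforhodamine B assay, with a stated time of 48 h; on this read-out higher numbers stand for weaker inhibition and lower numbers for stronger inhibition:
- compound 1 `O=C1NCCN1c1ccc(S(=O)(=O)Nc2ccc(C3CCCCC3)cc2)cc1`: > 1000 nM (a limit)
- compound 2 `CCc1ccc(NS(=O)(=O)c2ccc(N3CCNC3=O)cc2)cc1`: 810 nM
- compound 3 `O=C1NCCN1c1ccc(S(=O)(=O)Nc2ccccc2)cc1`: 470 nM

Compound 3 stands within the scatter of compound 2 and beyond the scatter of the limit held by compound 1. Compound 4 `CCCCOc1ccc(NS(=O)(=O)c2ccc(N3CCNC3=O)cc2)cc1` carries butoxy in place of hydrogen on an aromatic carbon of compound 3: butoxy in place of hydrogen on an aromatic carbon. Two measured steps end in hydrogen at this place and are read in reverse here. The step of a 1.7-fold lower number from compound 2 to compound 3 (0.24 log units; within the scatter) stays within the scatter, whereas the step of an at least 2.1-fold lower number from compound 1 to compound 3 (0.32 log units; beyond the scatter) goes beyond it. Neither involves butoxy, so the transfer is loose, but together they lead to the expectation of a modest rise in the number. The expected step is a 1.7-fold higher number from compound 3 to compound 4 (0.23 log units; within the scatter). Compound 4 is expected at 800 nM, with an estimated range of 300 nM to 2000 nM.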

Compound 4, half-maximal inhibitory concentration: 870 nM
The estimate for compound 4 lay 1.1-fold (0.04 log units) below the measured number, and the stated range covers the measured number.
By their numbers in this assay, from the lowest: compounds 3, 2 and 4 (each within the scatter of the next). At a limit, above all of these: compound 1.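

In this assay, butoxy, the only group shown that brings a hydrogen-bond acceptor to this aromatic carbon, gives a 1.9-fold higher number from compound 3 to compound 4 (0.27 log units; within the scatter). In place of ethyl it gives a 1.1-fold higher number from compound 2 to compound 4 (0.03 log units; within the scatter), so at this position, para to a large group, these compounds do not separate butoxy from ethyl. Compound 1 holds a limit, and an at least 1.1-fold lower number from compound 1 to compound 4 (0.06 log units; that floor lies within the scatter) is only a floor: the limit of > 1000 nM in this assay, at which 1 of the 4 values shown sits.

As far as these compounds go, whether an amine or a carboxylic acid at this carbon would give a step beyond the scatter stays open.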